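This account rests on a few compounds, and the source may have more. Where it says the series, first, only, none or still open, it means among the compounds named here.

Measured so far:
compound 1 `CC/C=C/C(=O)Nc1cc2c(N3CCc4ccccc43)ncnc2cc1O[C@@H]1CCOC1` — 8840 nM
compound 2 `CC/C=C/C(=O)Nc1cc2c(N3CCCc4ccccc43)ncnc2cc1O[C@@H]1CCOC1` — 14400 nM

In a functional assay on MCF7 cells (Homo sapiens) for antiproliferative activity, read by MTT assay, with a stated time of 72 h (on this read-out higher numbers stand for weaker inhibition and lower numbers for stronger inhibition), compound 1 holds the lowest of the two numbers; compound 2 is the nearest, with a 1.6-fold higher number from compound 1 to compound 2 (0.21 log units; within the scatter).

Compound 3 `O=C(/C=C/CN1CCCCC1)Nc1cc2c(N3CCc4ccccc43)ncnc2cc1O[C@@H]1CCOC1` differs from compound 1 by piperidin-1-yl in place of methyl on a saturated chain carbon bound to a double-bonded chain carbon. Among the compounds with values here, the single measured step, a 1.6-fold higher number from compound 1 to compound 2 (0.21 log units; within the scatter), concerns the amine on the shared core and not the acrylamide chain, so no measured step bears on this change. With nothing to go on beyond compound 1 itself, the expected step of a 1.3-fold lower number from compound 1 to compound 3 (0.10 log units; within the scatter) is none beyond the scatter, and the estimate is taken wide. Compound 3 is expected at 7000 nM, within 1500 nM to 30000 nM.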

Compound 3, half-maximal inhibitory concentration: 1890 nM
Estimate against measurement, compound 3: 3.7-fold (0.57 log units) above; the measured number falls inside the stated range.
By their numbers in this assay, from the lowest: compound 3; then compounds 1 and 2 (each within the scatter of the next).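

Within the data shown here, on this assay the saturated chain carbon bound to a double-bonded chain carbon tolerates a much larger group: piperidin-1-yl in place of methyl gives a 4.7-fold lower number from compound 1 to compound 3 (0.67 log units; beyond the scatter) and is the first step to lie beyond the scatter. The earlier step, at the other place of change on the shared core, stayed within it. Nothing at hand accounts for this step.

Still open, on these data alone, is whether the step belongs to piperidin-1-yl itself or would also come with another amine here, such as morpholin-4-yl or dimethylamino. Also open, as far as these compounds go, is whether it carries over to the 1,2,3,4-tetrahydroquinolin-1-yl series of compound 2.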